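The source may hold more compounds than are shown below. What is called first, only, known or untested is meant among the compounds shown, and "the series" means these compounds.

Measured so far:
- compound 1 `CN(C)C(=O)CN1CCC(c2cc3c(-c4ccc(=O)n(C5CCOCC5)c4)ccnc3[nH]2)CC1`: 840000 nM
- compound 2 `COc1cc(F)ccc1-c1ccnc2[nH]c(C3CCN(C(C)=O)CC3)cc12`: 50000 nM

In a physicochemical assay for solubility, in phosphate buffer, at pH 7.4 (a lower number here means a less soluble compound, a higher number a more soluble compound), compound 1 stands highest of the two measured compounds, and compound 2 lies below it, beyond the scatter. Compound 3 `CN(C)C(=O)CN1CCC(c2cc3c(-c4ccc(=O)n(C5CCC5)c4)ccnc3[nH]2)CC1` keeps the core of compound 1 but carries cyclobutyl in place of oxan-4-yl on an aromatic nitrogen. Among the compounds with values here, no measured pair shows this change, so the expectation is a judgement from the change alone: a modest fall in this assay, close to the usual scatter. The expected step is a 2.1-fold lower number from compound 1 to compound 3 (0.32 log units; beyond the scatter). For compound 3 the estimated value is 400000 nM, within an expected range of 130000 nM to 900000 nM.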

Compound 3, solubility: > 1000000 nM
Compound 3 was reported as a limit; the forecaster's own chance of this, stated with the estimate: 15%; middle value at least 2.5-fold (0.39 log units) from the limit.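

In this assay compound 3 gives > 1000000 nM, which is a limit of the assay and not a number. Cyclobutyl in place of oxan-4-yl on the aromatic nitrogen gives an at least 1.1-fold higher number from compound 1 to compound 3 (0.07 log units; that floor lies within the scatter), so only a floor for this step can be read. Removing the oxygen-bearing ring at this position brought no fall in this assay, and the reading reaches the top of its range: the limit of > 1000000 nM in this assay, at which 1 of the 3 values shown sits.

Going by these compounds, the true size of the step stays open. On these data alone, whether an amine or a longer chain on this aromatic nitrogen would read the same in this assay also stays open.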